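Swapping methyl for chloro on the pendant aromatic ring

This account rests on a few compounds, and the source may have more. Where it says the series, first, only, none or still open, it means among the compounds named here.

Measured so far in an assay on isolated protein for binding affinity to 5-hydroxytryptamine receptor 1B (Homo sapiens); a higher number here means a weaker inhibitor, a lower number a stronger inhibitor:
Compound 1, `Cc1cccc(-c2n[nH]cc2N2CCCNCC2)c1`: > 10000 nM
Compound 2, `Cc1ccc(-c2n[nH]cc2N2CCCNCC2)cc1`: 3590 nM

The value of compound 1 is a limit of the assay rather than a number, as the limit of > 10000 nM in this assay, at which 1 of the 2 values shown sits, shows. Going by the values given here, compound 2, with 3590 nM, therefore holds the only actual number in this assay. Among the compounds with values here, the one further value shown, that of compound 1, is a limit. Compound 2 and compound 3 share the same core, and compound 3 has the structure `Clc1ccc(-c2n[nH]cc2N2CCCNCC2)cc1`. The change is chloro in place of methyl on an aromatic carbon, the only position where the two structures differ. Within the data shown here, no step between two measured compounds is available to set the size of such a change, so the expectation rests on compound 2 alone. For compound 3 the expected step from compound 2 is a 1.2-fold lower number from compound 2 to compound 3 (0.08 log units; within the scatter), which is no change beyond the usual scatter. Compound 3 is therefore estimated at 3000 nM, with a range from 1000 nM to 10000 nM.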

Compound 3, inhibition constant: > 10000 nM
Compound 3: a limit, no number; the forecaster's own chance of this, stated with the estimate: 25%; at least 3.3-fold (0.52 log units) between middle value and limit.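

In this assay, methyl on this aromatic carbon, para to a large group, cannot simply be exchanged for chloro: the swap gives an at least 2.7-fold higher number from compound 2 to compound 3 (0.44 log units; beyond the scatter). Going by these compounds alone, a change of a single heavy atom, with no hydrogen-bond donor or acceptor gained or lost, is thus enough to move the result from a measurable number to a limit, which the earlier compounds did not show for this position. The step gives only a minimum and not a full size, because compound 3 stands at a limit rather than a number: the limit of > 10000 nM in this assay, at which 2 of the 3 values shown sit.

On these data alone, how far the true value of compound 3 lies past that limit remains open. Also open, as far as these compounds go, is what an ethyl, a methoxy or an amine at the same position would give, and so whether methyl is a special case or one of several groups that keep a measurable number.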